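This account rests on a few compounds, and the source may have more. Where it says the series, first, only, none or still open, it means among the compounds named here.

Compounds measured in a functional assay on DU-145 cells (Homo sapiens) for antiproliferative activity, read by sulforhodamine B assay, with a stated time of 72 h; on this read-out lower numbers stand for stronger inhibition of growth and higher numbers for weaker inhibition of growth:

compound 1, `COc1ccc(Br)c(CSc2ccc3c(C)cc(=O)oc3c2)c1`, > 25500 nM
compound 2, `CCc1cc(=O)c2ccc(Sc3cccc(Cl)n3)cc2o1`, > 31400 nM
compound 3, `CCc1cc(=O)c2ccc(OCc3ccccc3)c(C)c2o1`, 27700 nM

The value given for compound 1 is a limit of this assay and not a number, (the limit of > 25500 nM in this assay, at which 1 of the 3 values shown sits). The value given for compound 2 is likewise a limit and not a number, (the limit of > 31400 nM in this assay, at which 1 of the 3 values shown sits). For the measured compounds named here, compound 3 is therefore the only compound of the three with an actual measured number for growth inhibition, and that number stands at the weak end of what this assay reports. Going by the values given here, with no two measured compounds differing in a single place, no step can be sized.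

Compound 4, `CCc1cc(=O)c2ccc(OCc3cccc(C#N)c3)c(C)c2o1`, differs from compound 3 in one place: cyano in place of hydrogen on an aromatic carbon, meta to a large group on the outer ring. Among the compounds with values here, nothing among the measured compounds shows what a cyano group does here, so the expectation rests on the size of the change alone. Compound 4 is estimated to give 22000 nM, with a range from 8000 nM to 60000 nM. The expected step of a 1.3-fold lower number from compound 3 to compound 4 (0.10 log units; within the scatter) is small and stays within the usual scatter of this assay, with no clear direction either way.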

Compound 4, concentration for 50% growth inhibition: > 31300 nM
Compound 4: a limit, no number (the forecaster's own chance of this, stated with the estimate: 35%); middle value at least 1.4-fold (0.15 log units) away from the limit.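

In this assay, for the compounds shown here, the change from phenyl to 3-cyanophenyl gives the first step that can be read: an at least 1.1-fold higher number from compound 3 to compound 4 (0.05 log units; that floor lies within the scatter). Compound 4 reads as a limit and not a number: the limit of > 31300 nM in this assay, at which 1 of the 4 values shown sits. The step is therefore only a floor, so it shows that cyano in place of hydrogen on this aromatic carbon, meta to a large group, did not bring compound 4 to a measured number in this assay, but it does not give the true size of the change.

The compounds shown leave open what cyano would do elsewhere on the outer ring, and whether an amine, a carboxylic acid or a methoxy group at this same place would give a measured number at all. Going by these compounds alone, compounds 1 and 2 differ from the others in more than one place and also read as limits, so no steps involving them can be read, and the effect of changes to the shared core remains unknown.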